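This account rests on a few compounds, and the source may have more. Where it says the series, first, only, none or still open, it means among the compounds named here.

Measured so far:

compound 1, `COc1ccc(-c2c(S(=O)(=O)c3ccc(C)c(F)c3)cnc3c(F)cccc23)cc1`, with 3.27 mL/min
compound 2, `COc1ccc(-c2c(S(=O)(=O)c3ccc(OC)cc3)cnc3c(F)cccc23)cc1`, with 2.12 mL/min
compound 3, `COc1ccc(S(=O)(=O)c2cnc3cc(F)ccc3c2-c2cccc(F)c2)cc1`, with 2.94 mL/min

These three compounds were run through an ADME assay on microsomes from liver (Homo sapiens) for metabolic stability, tested at 2.5 uM; a higher number here means faster removal of the compound, a lower number slower removal. Compound 2 and compound 1 share one core and differ only in the group on the sulfonyl sulfur; the change is 3-fluoro-4-methylphenyl in place of 4-methoxyphenyl on a sulfonyl sulfur. The step it made is a 1.5-fold higher number from compound 2 to compound 1 (0.19 log units; within the scatter), so the two numbers are not told apart by this assay.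

Compound 3 carries a different core. How the core of compound 3 differs from that of compound 2 is not broken down here. In this assay compound 3 gives a number close to those of compound 1 and compound 2, all three within the scatter of one another.

Compound 4, `Cc1ccc(S(=O)(=O)c2cnc3cc(F)ccc3c2-c2cccc(F)c2)cc1F`, has not yet been measured. It differs from compound 3 by 3-fluoro-4-methylphenyl in place of 4-methoxyphenyl on a sulfonyl sulfur, which is the same change as that from compound 2 to compound 1, made at the same kind of place, the sulfonyl sulfur whose other neighbour is an aromatic carbon. Among the compounds with values here, the one earlier example of this change, from compound 2 to compound 1, stayed within the scatter, so on a different core the same small step is expected here: a 1.4-fold higher number from compound 3 to compound 4 (0.13 log units; within the scatter). The expected result for compound 4 in this assay is 4 mL/min, with a likely range from 2.5 mL/min to 6.5 mL/min, resting on the value of compound 3, 2.94 mL/min, and on the earlier step of a 1.5-fold higher number from compound 2 to compound 1 (0.19 log units; within the scatter).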

Compound 4, intrinsic clearance in a liver preparation (reported as CLH), per the amount of preparation that the assay uses: 0.41 mL/min
For compound 4 the middle estimate is 9.8-fold (0.99 log units) above the measured one, outside the stated range (below it).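

In this assay, putting 3-fluoro-4-methylphenyl in place of 4-methoxyphenyl on the sulfonyl sulfur gave a 7.2-fold lower number from compound 3 to compound 4 (0.86 log units; beyond the scatter), a clear step on this core, whereas the same swap on the core of compound 1 was not told apart from the scatter. The result of this change on one core therefore did not carry over to the other, and the two steps truly differ: the same change on two cores in this assay, a 1.5-fold higher number (0.19 log units; within the scatter) from compound 2 to compound 1 and a 7.2-fold lower number (0.86 log units; beyond the scatter) from compound 3 to compound 4, 11-fold (1.04 log units) apart, beyond the scatter of two such steps. This shows that, in this series, the step seen on one core is a poor guide to the step on another, but it does not show why the two cores part ways, and with just one pair on each core it gives no general rule for other cores.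

The compounds shown leave open whether the fluoro or the methyl part of the 3-fluoro-4-methylphenyl group carries the step on the core of compound 3, as no compound here has one without the other. They also leave open how this assay would read on either core with an amine or a carboxylic acid on the ring attached to the sulfonyl sulfur.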